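The source may hold more compounds than are shown below. What is called first, only, known or untested is meant among the compounds shown, and "the series" means these compounds.

The account starts from compound 1 `COc1c(OCCCN2CCNCC2)cc(O)c2c(=O)cc(-c3ccccc3)oc12`, which in a functional assay on A549 cells (Homo sapiens) for cytotoxicity, read by MTT assay, with a stated time of 48 h (on this read-out lower numbers stand for stronger inhibition and higher numbers for weaker inhibition), gives 10100 nM, the only numeric result among the three compounds measured. Compound 2 `CN(C)CCCCOc1c(O)cc(O)c2c(=O)cc(-c3ccccc3)oc12` reaches only a limit in this assay, namely (the limit of > 100000 nM in this assay, at which 1 of the 3 values shown sits), reported as > 100000 nM. For compound 3 `CC(C)NCCOc1c(O)cc(O)c2c(=O)cc(-c3ccccc3)oc12` this assay records "not determined" (no result reported). Compound 4 `COc1c(OCCCCNCc2ccccc2)cc(O)c2c(=O)cc(-c3ccccc3)oc12` has not been measured; it differs from compound 1 by (benzylamino)methyl in place of piperazin-1-yl on a saturated chain carbon, three bonds along the chain from an oxygen on an aromatic ring. For the measured compounds named here, no measured step of this kind exists here, so the expectation rests on compound 1 alone at 10100 nM, and a modest step toward stronger inhibition, not far beyond the usual scatter, is expected. Compound 4 is expected to give 5000 nM. For compound 4 the estimated range runs from 1500 nM to 20000 nM. The estimated step is a 2.0-fold lower number from compound 1 to compound 4 (0.31 log units; beyond the scatter).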

Compound 4, half-maximal inhibitory concentration: 4590 nM
Compound 4: the middle estimate sits 1.1-fold (0.04 log units) above what was measured; the range from low to high includes it.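

In this assay, putting (benzylamino)methyl in place of piperazin-1-yl on a saturated chain carbon, three bonds along the chain from an oxygen on an aromatic ring, brings a 2.2-fold lower number from compound 1 to compound 4 (0.34 log units; beyond the scatter). This first measured step at this place shows that it accepts a group carrying an aromatic ring of carbon only, with no loss of inhibition. Nothing given here accounts for the size of the step. From the compounds shown here alone, whether a morpholin-4-yl group, a carboxylic acid or a longer chain would move the number further stays open.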